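Hydroxy to Chloro at the Anilino Para Position

This account rests on a few compounds, and the source may have more. Where it says the series, first, only, none or still open, it means among the compounds named here.

Of the compounds shown here, three sharing one core have been measured in a functional assay on PC-3 cells (Homo sapiens) for inhibition, read by MTT assay, with a stated time of 72 h; on this read-out higher numbers stand for weaker inhibition and lower numbers for stronger inhibition. Compound 1 `COc1cc2c(Nc3ccc(Br)cc3Cl)ncnc2c(OC)c1OC` gives 21000 nM. Compound 2 `COc1cc2c(Nc3ccc([N+](=O)[O-])cc3)ncnc2c(OC)c1OC` gives 25500 nM. Compound 3 `COc1cc2c(Nc3ccc(O)cc3)ncnc2c(OC)c1OC` gives 20100 nM, a number that does not separate from either of the other two beyond the scatter. The step of a 1.0-fold lower number from compound 1 to compound 3 (0.02 log units; within the scatter) and the step of a 1.3-fold lower number from compound 2 to compound 3 (0.10 log units; within the scatter) both stay within the scatter, so the three compounds are indistinguishable on this read-out.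

Compound 4 `COc1cc2c(Nc3ccc(Cl)cc3)ncnc2c(OC)c1OC` has not been measured. It differs from compound 3 in one place: chloro in place of hydroxy on an aromatic carbon. The two measured steps into compound 3 each exchange a group at the same ring for hydroxy, and neither moved the number beyond the scatter; the present change reverses that direction with chloro. On that basis no step beyond the scatter is expected, and the estimated step is a 1.0-fold higher number from compound 3 to compound 4 (0.02 log units; within the scatter). Compound 4 is therefore expected to give about 21000 nM in this assay, within a range from 10000 nM to 45000 nM.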

Compound 4, half-maximal inhibitory concentration: 31000 nM
The estimate for compound 4 lay 1.5-fold (0.17 log units) below the measured number, within the range that was stated.
By their numbers in this assay, from the lowest: compounds 3, 1, 2 and 4 (each within the scatter of the next).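

In this assay, chloro in place of hydroxy on this aromatic carbon (a 1.5-fold higher number from compound 3 to compound 4 (0.19 log units; within the scatter)) removes a hydrogen-bond donor and a hydrogen-bond acceptor, yet the number stays within the scatter. The other two steps into compound 4, chloro in place of nitro (a 1.2-fold higher number from compound 2 to compound 4 (0.08 log units; within the scatter)) and 4-chlorophenyl in place of 4-bromo-2-chlorophenyl (a 1.5-fold higher number from compound 1 to compound 4 (0.17 log units; within the scatter)), also stay within the scatter, so none of the exchanges read so far, now including one into chloro, separates these compounds. Nothing measured here offers a reason for this lack of separation.

On these data alone, whether an amine, a carboxylic acid or a longer chain such as butoxy at this position would move the number beyond the scatter remains open. The compounds shown also leave open whether any change on this ring can separate one compound from another on this read-out.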